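The source may hold more compounds than are shown below. What is called first, only, known or untested is meant among the compounds shown, and "the series" means these compounds.

Working notes on the series. The shared core, seen in compound 1 `CN(C)C(=O)n1nnc(-c2ccc(Oc3ccc(Cl)cc3)cc2)n1` and compound 2 `CN(C)C(=O)n1nnc(-c2ccc(Oc3cccc(Cl)c3)cc2)n1`, carries a six-membered aromatic ring bearing a chlorophenoxy group, and both have been tested in an assay on microsomes from brain (strain Sprague-Dawley) for inhibition of Fatty-acid amide hydrolase 1 (Rattus norvegicus), read by HPLC, with stated times of 10 min and 45 min; a lower number here means a stronger inhibitor, a higher number a weaker inhibitor. In this assay compound 1 gives 16 nM; in the same assay compound 2 gives 9 nM. For the measured compounds named here, the single measured step, a 1.8-fold lower number from compound 1 to compound 2 (0.25 log units; within the scatter), moves the chlorine from one position of the phenoxy ring to another. Going by the values given here, on the numbers so far compound 2 carries the lower of the two values, but the gap to compound 1 is within the scatter, so no ranking is claimed.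

Compound 3 `CN(C)C(=O)n1nnc(-c2ccc(-n3cccn3)cc2)n1` is not yet measured in this assay. It differs from compound 2 by 1H-pyrazol-1-yl in place of 3-chlorophenoxy on an aromatic carbon. Among the compounds with values here, no measured step bears on this change: the one step in hand, from compound 1 to compound 2, only shifts a chlorine within the group that now leaves, and it stayed within the scatter. Replacing the whole 3-chlorophenoxy group by 1H-pyrazol-1-yl is therefore untested ground, and a loss of potency beyond the scatter is expected rather than a gain. The estimate for compound 3 in this assay is 50 nM, with a range from 10 nM to 300 nM. This estimate corresponds to an expected step of a 5.6-fold higher number from compound 2 to compound 3 (0.74 log units; beyond the scatter).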

Compound 3, half-maximal inhibitory concentration: 8 nM
The estimate for compound 3 lay 6.3-fold (0.80 log units) above the measured number, and the stated range ends above it.
By their numbers in this assay, from the lowest: compounds 3, 2 and 1 (each within the scatter of the next).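

At this aromatic carbon, the whole 3-chlorophenoxy group can be exchanged for 1H-pyrazol-1-yl in this assay with no change that the data can resolve (a 1.1-fold lower number from compound 2 to compound 3 (0.05 log units; within the scatter)). The comparison with the 4-chlorophenoxy group reads the same way (a 2.0-fold lower number from compound 1 to compound 3 (0.30 log units; within the scatter)), so within these three compounds neither the chlorine, the oxygen nor a six-membered aromatic ring of carbon only is required for a value in this range, and a group of 5 heavy atoms serves as well here as one of 8. No supporting data bear on why the exchange is tolerated.

The compounds shown leave open whether an aromatic ring is needed at this carbon at all, as against an amine such as morpholine or a short alkyl chain. They also leave open whether the values stay level when the 1H-pyrazol-1-yl ring itself carries a methyl group or a chlorine, and whether the dimethylamino group on the carbonyl can be replaced by a piperidine without a loss beyond the scatter.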